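Series notes: hydroxyphenyl-pyrazole cytotoxics, carbonyl ring variant

The compounds below may be only part of what the source reports. "The series", "measured", "known", "first", "only" and "open" are said of these compounds alone.

Measured compounds:
compound 1 `Oc1ccc(O)c(-c2cc(-c3ccc(Cl)cc3)nn2-c2ccccc2)c1` — 8860 nM
compound 2 `NS(=O)(=O)c1ccc(-n2nc(-c3ccc(Cl)cc3)cc2-c2cc(O)ccc2O)cc1` — 12000 nM

In a functional assay on cells (Cancer cell lines, Homo sapiens) for cytotoxicity, read by sulforhodamine B assay, with a stated time of 48 h (a higher number here means a weaker inhibitor of growth, a lower number a stronger inhibitor of growth), compound 1 gives 8860 nM and compound 2 gives 12000 nM; the two numbers differ only within the scatter, so compound 1 cannot be set apart from compound 2 on these data. Among the measured compounds shown here, the only measured step, a 1.4-fold higher number from compound 1 to compound 2 (0.13 log units; within the scatter), concerns the phenyl on the ring nitrogen and nothing else.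

Compound 3 `O=C1C=CC(=O)C(c2cc(-c3ccc(Cl)cc3)nn2-c2ccccc2)=C1` is reached from compound 1 by the change (a group of 8 heavy atoms (6 carbon, 2 oxygen; one six-membered non-aromatic ring of carbon only) in place of a group of 8 heavy atoms (6 carbon, 2 oxygen; one six-membered aromatic ring of carbon only), on an aromatic carbon). Both hydroxyls of the leaving group are gone and the entering ring carries the two oxygens as carbonyls with four double bonds outside aromatic rings. For the measured compounds named here, no measured step touches this position or this kind of exchange; the step from compound 1 to compound 2 does not bear on it, since it changes a different part of the molecule. The direction of the change in this assay is therefore open, and any expectation must be wide.

Working estimate: compound 3 is expected near compound 1 in this assay, with the step of a 1.3-fold lower number from compound 1 to compound 3 (0.10 log units; within the scatter), giving 7000 nM within 1500 nM to 30000 nM.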

Compound 3, concentration for 50% growth inhibition: 55600 nM
The estimate for compound 3 lay 7.9-fold (0.90 log units) below the measured number; measured number outside the range, above it.
By their numbers in this assay, from the lowest: compounds 1 and 2 (each within the scatter of the next); then compound 3.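

In this assay, the step at this position is a 6.3-fold higher number from compound 1 to compound 3 (0.80 log units; beyond the scatter), with the 2,5-dihydroxyphenyl group giving way to the non-aromatic ring of carbon that carries its oxygens as carbonyls. The position on the five-membered aromatic ring therefore responds to this exchange, whereas the earlier change on the phenyl group, a 1.4-fold higher number from compound 1 to compound 2 (0.13 log units; within the scatter), left the number within the scatter. The exchange removes the aromatic ring and takes the hydrogen-bond donors from 2 to 0 while the heavy-atom count stays the same, but no measurement in hand ties the step to either difference or to any other property.

Open, from the compounds shown here alone, is whether the loss of the hydroxyls or the loss of the aromatic ring carries the step, since both change together here; an unsubstituted phenyl or a 2,5-dimethoxyphenyl group at this position would separate the two. Also open, going by these compounds, is whether the same exchange gives a step of similar size when the phenyl group carries the sulfamoyl substituent of compound 2.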